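The compounds below may be only part of what the source reports. "The series", "measured", "known", "first", "only" and "open" are said of these compounds alone.

In a functional assay on OVCAR-3 cells (Homo sapiens) for cytotoxicity, read by sulforhodamine B assay (on this read-out lower numbers stand for higher toxicity in this test and higher numbers for lower toxicity in this test), compound 1 `CC1=CC[C@@H]([C@@](C)(O)CCCC(C)(C)NC(=S)NN)CC1` gives > 100000 nM, which is a limit of the assay and not a number. Compound 2 `CC1=CC[C@@H]([C@@](C)(O)CCCC(C)(C)NC(=S)N/N=C\c2ccc([N+](=O)[O-])cc2)CC1` gives > 100000 nM, again a limit. Compound 3 `CC1=CC[C@@H]([C@@](C)(O)CCCC(C)(C)NC(=S)N/N=C\c2ccccc2Cl)CC1` gives > 100000 nM, also a limit, so it stands without a number of its own. The picture so far is a single one: the limit of > 100000 nM in this assay, at which 3 of the 3 values shown sit.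

Compound 4 `CC1=CC[C@@H]([C@@](C)(O)CCCC(C)(C)NC(=S)N/N=C\c2cccc(Cl)c2)CC1` differs from compound 3 in one place: 3-chlorophenyl in place of 2-chlorophenyl on a carbon with a double bond to nitrogen. It has 3-chlorophenyl in place of 2-chlorophenyl on a carbon with a double bond to nitrogen.

Among the measured compounds shown here, two measured steps bear on this change. The closer one, at the same place, is a step that the two limits leave unreadable from compound 2 to compound 3. The other is a step that the two limits leave unreadable from compound 1 to compound 3. Neither has a size that can be read, so they give no measure of how far such a change might move the value in this assay.

The expectation therefore rests on (the limit of > 100000 nM in this assay, at which 3 of the 3 values shown sit), and no shift beyond the scatter is expected in either direction. The expected step is a number no higher from compound 3 to compound 4 (the limit leaves the size open). Compound 4 is most likely to stay at the limit as well. For compound 4 the estimated value is 100000 nM, with an expected range from 40000 nM to 150000 nM.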

Compound 4, concentration lethal to 50% of the cells: 48000 nM
Compound 4: middle estimate off by 2.1-fold (0.32 log units), on the high side; the measured number falls inside the stated range.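

In this assay, compound 4 is the first of the compounds shown to give a number rather than a limit, so this position on the carbon with a double bond to nitrogen is not indifferent to the change: with the same atoms joined differently, 3-chlorophenyl in place of 2-chlorophenyl gives an at least 2.0-fold lower number from compound 3 to compound 4 (0.31 log units; beyond the scatter). The same group in place of 4-nitrophenyl gives an at least 2.0-fold lower number from compound 2 to compound 4 (0.31 log units; beyond the scatter), and the whole group in place of one nitrogen atom, on the amide-type nitrogen, gives an at least 2.0-fold lower number from compound 1 to compound 4 (0.31 log units; beyond the scatter). Each of these steps starts from a limit of the assay, so each gives only a smallest size, and compound 4 alone has left the picture that held so far: the limit of > 100000 nM in this assay, at which 3 of the 4 values shown sit.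

The compounds shown leave open whether the lower number belongs to chlorine at this ring position in particular or would also come with 3-bromophenyl or 3-methoxyphenyl at the same place. They also leave open how 4-chlorophenyl would read, which would show whether the 4-nitrophenyl of compound 2 stays at the limit through its position or through the nitro group itself.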